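A Growth Limit and an Unmeasured Ester

A few compounds are considered here, and "the series" means these few. Any claim that something is new, unique, unknown or untested is made for them only; others in the source may bear on it.

Measured so far in a functional assay on HCT-116 cells (Homo sapiens) for inhibition, read by MTT assay, with a stated time of 72 h; a lower number here means a stronger inhibitor of growth, a higher number a weaker inhibitor of growth:
Compound 1 `NNC(=O)CCc1ccncc1-c1ccc2ccccc2c1`: > 30000 nM (a limit of the assay)
Compound 2 `O=C(/C=C/c1ccncc1-c1ccc2[nH]ccc2c1)N1CCOCC1`: "not determined" (no result reported)

In this assay compound 1 stands at > 30000 nM, which is a limit and not a number. The measured record amounts to the limit of > 30000 nM in this assay, at which 1 of the 2 values shown sits, and compound 2 offers no figure to set beside it.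

Compound 3 `CCOC(=O)/C=C/c1ccncc1-c1ccc2ccccc2c1` awaits measurement. In it, 2-(ethoxycarbonyl)ethenyl takes the place of the 2-(aminocarbamoyl)ethyl of compound 1 on an aromatic carbon, opposite the ring nitrogen: 2-(ethoxycarbonyl)ethenyl in place of 2-(aminocarbamoyl)ethyl on an aromatic carbon. Going by the values given here, no measured step shows what such an exchange does. The expectation rests on compound 1 alone, whose > 30000 nM is a limit, so a weak inhibitor of growth is expected again. In this assay the estimated change is an at least 1.2-fold lower number from compound 1 to compound 3 (0.07 log units; that floor lies within the scatter), and none beyond the scatter is expected in either direction. Compound 3 is estimated at 25000 nM, with an expected range from 6000 nM to 50000 nM.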

Compound 3, concentration for 50% growth inhibition: 910 nM
For compound 3 the middle estimate is 27-fold (1.44 log units) above the measured one, outside the stated range (below it).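

In this assay, 2-(ethoxycarbonyl)ethenyl in place of 2-(aminocarbamoyl)ethyl on the aromatic carbon opposite the ring nitrogen gives an at least 32-fold lower number from compound 1 to compound 3 (1.51 log units; beyond the scatter), which shows that the number responds strongly to the group at this position. Going by these compounds alone, the size of this step is a floor and not a measured gap, as the value of compound 1 is a limit of the assay: the limit of > 30000 nM in this assay, at which 1 of the 3 values shown sits. The two groups differ at once in heavy atoms, double bonds outside aromatic rings and hydrogen-bond donors, and the single step does not separate these differences.

On these data alone, it remains open whether the step belongs to the ethyl ester or to the double bond of the chain. A carboxylic acid or a 2-(ethoxycarbonyl)ethyl group at this position on the shared core would bear on that question.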